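This account rests on a few compounds, and the source may have more. Where it says the series, first, only, none or still open, it means among the compounds named here.

Measured so far:
Compound 1, `CCCCCN(C)/N=N/c1nc[nH]c1C(N)=O`, gives 3.58 in a functional assay on L1210 cells (Mus musculus) for antiproliferative activity; a higher number here means a more potent compound, by a factor of ten per unit of this negative logarithm, a lower number a less potent compound.
Compound 2, `CN(/N=N/c1nc[nH]c1C(N)=O)c1cccs1`, gives 3.87.
Compound 3, `CCCN(C)/N=N/c1nc[nH]c1C(N)=O`, gives 3.58.

Compound 3 is level with compound 1 at the digits shown, and these two stand together as the lowest of the three numbers; its gap to compound 2 stays within the scatter, a number 0.29 log units lower from compound 2 to compound 3 (within the scatter).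

Compound 4, `CCCCCCCCN(C)/N=N/c1nc[nH]c1C(N)=O`, has not yet been measured. The change is pentyl in place of hydrogen on a saturated chain carbon, three bonds along the chain from an amine nitrogen. Among the measured compounds shown here, one measured step bears on this: shortening the chain from compound 1 to compound 3 gave no change at the digits printed from compound 1 to compound 3 (within the scatter). Lengthening the chain is therefore expected to make no difference beyond the scatter, a number 0.02 log units higher from compound 3 to compound 4 (within the scatter). Compound 4 is expected at 3.6, with a range from 3.2 to 4.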

Compound 4, logarithm of the reciprocal of the active concentration, log(1/C): 3
For compound 4 the middle estimate is 0.60 log units above the measured one, and the stated range ends above it.
By their numbers in this assay, from the lowest: compound 4; then compounds 1, 3 and 2 (each within the scatter of the next).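

In this assay, pentyl in place of hydrogen gives a number 0.58 log units lower from compound 3 to compound 4 (beyond the scatter) and propyl in place of hydrogen gives a number 0.58 log units lower from compound 1 to compound 4 (beyond the scatter) at the chain on the amine nitrogen. The earlier pair of chains showed no response to length, so this position does respond once the chain grows beyond that of compound 1. No measurement here accounts for the drop.

A hexyl or heptyl chain on that nitrogen would help show where the fall begins. On these data alone, it also remains open whether a chain ending in an amine or a carboxylic acid would keep the number of compound 4 or restore that of compound 1.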